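Ethyl to Tert-Butyl on the Amide of Compound 3

This account rests on a few compounds, and the source may have more. Where it says the series, first, only, none or still open, it means among the compounds named here.

Compound 1 `CC(C)c1ccccc1OS(=O)(=O)c1cccc(NC(=O)CCl)c1`: 4500 nM
Compound 2 `CCC(=O)Nc1ccc(S(=O)(=O)Oc2ccccc2C(C)C)cc1`: 7400 nM
Compound 3 `CCC(=O)Nc1ccc(S(=O)(=O)Oc2ccccc2I)cc1`: 11000 nM

In a functional assay on HT-29 cells (Homo sapiens) for antiproliferative activity, read by sulforhodamine B assay, with a stated time of 48 h (on this read-out higher numbers stand for weaker inhibition and lower numbers for stronger inhibition), compound 3 gives the highest of the three numbers. Compound 2 stands nearest to it, as seen in a 1.5-fold higher number from compound 2 to compound 3 (0.17 log units; within the scatter), a step that lies within the scatter; compound 1 stands furthest from compound 3, beyond the scatter. Compound 4 `CC(C)(C)C(=O)Nc1ccc(S(=O)(=O)Oc2ccccc2I)cc1` differs from compound 3 in one place: tert-butyl in place of ethyl on a carbonyl carbon. Within the data shown here, the only measured step, a 1.5-fold higher number from compound 2 to compound 3 (0.17 log units; within the scatter), concerns a group on an aromatic carbon, not the amide, so nothing measured here bears directly on this change. For compound 4 a step of no change at the digits printed from compound 3 to compound 4 (within the scatter) is therefore expected, which is no move beyond the scatter. Compound 4 is thus estimated at 11000 nM, with a range from 4000 nM to 30000 nM.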

Compound 4, half-maximal inhibitory concentration: 9500 nM
Compound 4: the middle estimate sits 1.2-fold (0.06 log units) above what was measured, and the stated range covers the measured number.
By their numbers in this assay, from the lowest: compounds 1, 2, 4 and 3 (each within the scatter of the next, the first and the last beyond it).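

In this assay, putting tert-butyl in place of ethyl on the carbonyl carbon gives a 1.2-fold lower number from compound 3 to compound 4 (0.06 log units; within the scatter), so this site on the amide accepts tert-butyl with no change that can be told from the scatter. Among these compounds, this is the first measured step at the amide, as the earlier step concerned a group on an aromatic carbon. Nothing available here offers a reason for this result.

As far as these compounds go, whether an amine, a carboxylic acid or a longer chain on this carbonyl carbon would leave the number equally unmoved stays open. From the compounds shown here alone, it is also open whether tert-butyl would behave the same way with the isopropyl group of compound 2 in place of iodo.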